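The source may hold more compounds than are shown below. What is called first, only, known or untested is meant among the compounds shown, and "the series" means these compounds.

Compound 1 `O=C(NNC(=O)c1cc([N+](=O)[O-])c[nH]1)Nc1ccc([N+](=O)[O-])cc1` gives 211000 nM
Compound 2 `O=C(NNC(=O)c1cc([N+](=O)[O-])c[nH]1)Nc1ccc(Cl)cc1` gives 218000 nM

In an ADME assay on Vero cells (Chlorocebus sabaeus) for cytotoxicity, read by MTT assay, with a stated time of 72 h (a lower number here means a stronger inhibitor, a higher number a weaker inhibitor), compound 2 gives 218000 nM and stands level, within the scatter, with compound 1 at 211000 nM in this small set. Compound 3 `COc1ccc(NC(=O)NNC(=O)c2cc([N+](=O)[O-])c[nH]2)cc1` has methoxy in place of chloro on an aromatic carbon. Among the measured compounds shown here, one measured step bears on this: chloro in place of nitro, a 1.0-fold higher number from compound 1 to compound 2 (0.01 log units; within the scatter), stayed within the scatter. On that single step, no change beyond the scatter is expected in this assay. The expected step is a 1.1-fold lower number from compound 2 to compound 3 (0.04 log units; within the scatter) and lies within the scatter. For compound 3 the estimated value is 200000 nM, with an expected range of 100000 nM to 380000 nM.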

Compound 3, half-maximal inhibitory concentration: 401000 nM
Estimate against measurement, compound 3: 2.0-fold (0.30 log units) below; measured number above the stated range.
By their numbers in this assay, from the lowest: compounds 1, 2 and 3 (each within the scatter of the next).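

In this assay, methoxy on the aromatic carbon para to a large group stays within the scatter against both chloro (a 1.8-fold higher number from compound 2 to compound 3 (0.26 log units; within the scatter)) and nitro (a 1.9-fold higher number from compound 1 to compound 3 (0.28 log units; within the scatter)). Among the compounds shown here, this position has now carried three different groups, including one that adds a hydrogen-bond acceptor relative to chloro, and no step among compound 1, compound 2 and compound 3 lies beyond the scatter. No evidence bears on this result. Going by these compounds, whether an amine, a carboxylic acid or a longer chain here would give a step beyond the scatter remains open. So does the effect of any change elsewhere on the shared core.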